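Extending the Chain to the Hydroxycarbamoyl Group in Compound 1

The source may hold more compounds than are shown below. What is called first, only, known or untested is meant among the compounds shown, and "the series" means these compounds.

Compound 1 `Nc1nc2cc(-c3nn(CCCC(=O)NO)c4ncnc(N)c34)ccc2o1` carries a hydroxycarbamoyl group on a short chain. In a functional assay on A549 cells (Homo sapiens) for inhibition, read by MTT assay, with a stated time of 72 h (on this read-out lower numbers stand for stronger inhibition and higher numbers for weaker inhibition), compound 1 gives > 100000 nM, which is a limit of the assay and not a number. Two relatives on a different core were measured alongside. Compound 2 `Nc1ncnc2c1c(-c1cnc3[nH]ccc3c1)nn2CCCCCC(=O)NO` gives in this assay > 150000 nM, again a limit. Compound 3 `Nc1ncnc2c1c(-c1cnc3[nH]ccc3c1)nn2CCC(=O)NO` gives in this assay > 150000 nM, also a limit. For the measured compounds named here, the one step among them, a step that the two limits leave unreadable from compound 2 to compound 3, therefore cannot be read. Compound 1 thus stands at the limit of > 100000 nM in this assay, at which 1 of the 3 values shown sits, while the other two sit at the limit of > 150000 nM in this assay, at which 2 of the 3 values shown sit; since all three values are limits, none of the compounds can be called stronger or weaker than another.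

Compound 4 `Nc1nc2cc(-c3nn(CCCCCCC(=O)NO)c4ncnc(N)c34)ccc2o1` is not yet measured. It differs from compound 1 in one place: 3-(hydroxycarbamoyl)propyl in place of hydroxycarbamoyl on a saturated chain carbon, three bonds along the chain from an aromatic nitrogen. No measured step bears on this change, because the only step shown is unreadable, so nothing indicates how large the change should be or in which direction. The expected step is a number no higher from compound 1 to compound 4 (the limit leaves the size open). For compound 4 the estimate in this assay is 100000 nM, within 5000 nM to 300000 nM, with a real chance that only a limit is reported again.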

Compound 4, half-maximal inhibitory concentration: 33000 nM
Beside the measured number, compound 4's estimate is 3.0-fold (0.48 log units) above it; measured number inside the range.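

In this assay, for the compounds shown here, exchanging 3-(hydroxycarbamoyl)propyl for 6-(hydroxycarbamoyl)hexyl on the core of compound 1 gives an at least 3.0-fold lower number from compound 1 to compound 4 (0.48 log units; beyond the scatter), the first step in this set that can be read at all. Chain length at this place, on a saturated chain carbon, can therefore change the read-out on this core, something the unreadable step between the earlier compounds on the other core could not show. The true size of the step stays open, since compound 1 holds only a limit of the assay: the limit of > 100000 nM in this assay, at which 1 of the 4 values shown sits.

The compounds shown leave open whether a longer chain, or a carboxylic acid in place of the hydroxycarbamoyl group, would lower the number further on this core. They also leave open whether 6-(hydroxycarbamoyl)hexyl would have a similar effect on the core of compound 2.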